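Sec-butyl to tert-butyl: a small step expected

A few compounds are considered here, and "the series" means these few. Any claim that something is new, unique, unknown or untested is made for them only; others in the source may bear on it.

Compound 1 `CCCOC(=O)c1cc(N2C(=O)C3=C(CCCC3)C2=O)ccc1Cl` gives 1120 nM
Compound 2 `CCC(C)OC(=O)c1cc(N2C(=O)C3=C(CCCC3)C2=O)ccc1Cl` gives 1100 nM

In a functional assay on the whole organism for inhibition, with Scenedesmus acutus as the target (a lower number here means a stronger inhibitor, a higher number a weaker inhibitor), compound 2 gives 1100 nM and stands level with compound 1 within the scatter. Compound 3 `CC(C)(C)OC(=O)c1cc(N2C(=O)C3=C(CCCC3)C2=O)ccc1Cl` has tert-butyl in place of sec-butyl on an oxygen next to a carbonyl group. Within the data shown here, the one measured step (a 1.0-fold lower number from compound 1 to compound 2 (0.01 log units; within the scatter)) bears on this chain and lay within the scatter. Among the measured compounds shown here, no measured compound carries tert-butyl, so this evidence is thin. The expected step (a 1.2-fold higher number from compound 2 to compound 3 (0.07 log units; within the scatter)) stays within the scatter in this assay in either direction. For compound 3 the estimated value is 1300 nM (500 nM to 3200 nM).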

Compound 3, half-maximal inhibitory concentration: 81300 nM
Compound 3: middle estimate off by 63-fold (1.80 log units), on the low side; measured number above the stated range.
By their numbers in this assay, from the lowest: compounds 2 and 1 (each within the scatter of the next); then compound 3.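

Going to tert-butyl gives a 74-fold higher number from compound 2 to compound 3 (1.87 log units; beyond the scatter) and a 73-fold higher number from compound 1 to compound 3 (1.86 log units; beyond the scatter) in this assay even though the earlier change from propyl to sec-butyl stayed within the scatter. So this position on the oxygen is far less forgiving than the first pair suggested: sec-butyl and tert-butyl hold the same four carbons, and their arrangement alone separates compound 2 from compound 3.

Going by these compounds, whether a cyclopentyl or isopropyl group on this oxygen would stay level with compound 2 or fall away like compound 3 remains open. No measurement shown explains the size of this jump.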